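The source may hold more compounds than are shown below. What is called first, only, known or untested is meant among the compounds shown, and "the series" means these compounds.

In a functional assay on NCI-H460 cells (Homo sapiens) for inhibition, read by MTT assay, with a stated time of 4 days (on this read-out higher numbers stand for weaker inhibition and lower numbers for stronger inhibition), compound 3 `COc1cc(NC(C)CCCNC(=O)NNC(=O)NCCO)c2ncccc2c1` gives > 100000 nM, which is a limit of the assay and not a number. Compound 2 `COc1cc(NC(C)CCCNC(=O)NNC(=O)NCCCO)c2ncccc2c1` also gives > 100000 nM in this assay, again only a limit. Compound 1 `COc1cc(NC(C)CCCNC(=O)Nc2ccc(Cl)c(C(F)(F)F)c2)c2ncccc2c1`, which carries 4-chloro-3-(trifluoromethyl)phenyl on an amide-type nitrogen, gives 28000 nM in this assay. The two steps away from compound 1, an at least 3.5-fold higher number from compound 1 to compound 2 (0.55 log units; beyond the scatter) and an at least 3.5-fold higher number from compound 1 to compound 3 (0.55 log units; beyond the scatter), both run into the limit of > 100000 nM in this assay, at which 2 of the 3 values shown sit, and can only be read as at least modest. The step that the two limits leave unreadable from compound 2 to compound 3 cannot be sized because the limit of > 100000 nM in this assay, at which 2 of the 3 values shown sit, holds both of its compounds.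

Compound 4 `COc1cc(NC(C)CCCNC(=O)NNC(=O)NC(CO)(CO)CO)c2ncccc2c1` differs from compound 3 by 2-hydroxy-1,1-bis(hydroxymethyl)ethyl in place of 2-hydroxyethyl on an amide-type nitrogen. For the measured compounds named here, no measured step changes this hydroxylated chain in a compound that lies off the limit, so nothing in the data points to a recovery of inhibition. The step from compound 3 is therefore expected to be a step that the limit leaves unreadable from compound 3 to compound 4, none beyond the scatter. Compound 4 is expected to give 150000 nM, within 60000 nM to 400000 nM, most probably reported again only as a limit.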

Compound 4, half-maximal inhibitory concentration: > 100000 nM
Compound 4: a limit, no number (the forecaster's own chance of this, stated with the estimate: 85%); the middle value lies beyond the limit too.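

In this assay, compound 4 joins compound 2 and compound 3 at the limit, so a larger hydroxylated group on this amide-type nitrogen, 2-hydroxy-1,1-bis(hydroxymethyl)ethyl, also gives no readable number: the limit of > 100000 nM in this assay, at which 3 of the 4 values shown sit. Measured against the 4-chloro-3-(trifluoromethyl)phenyl group, this change gives an at least 3.5-fold higher number from compound 1 to compound 4 (0.55 log units; beyond the scatter), and that size is only a bound. The steps to compound 4 from compound 2 and from compound 3 cannot be read, as both ends of each are limits.

On these data alone, it remains open whether an amine or a carboxylic acid at the end of this chain would give a number and not a limit. As far as these compounds go, it is also open whether a plain phenyl group in place of 4-chloro-3-(trifluoromethyl)phenyl would keep a readable value.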